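From a fluoro to a nitro: what compound 4 may show

This account rests on a few compounds, and the source may have more. Where it says the series, first, only, none or still open, it means among the compounds named here.

compound 1 `CCOC(=O)C1=C(Nc2ccccc2)S/C(=C\c2ccc[nH]2)C1=O`: 18.3%
compound 2 `CCOC(=O)C1=C(Nc2ccc(F)cc2)S/C(=C\c2ccc[nH]2)C1=O`: < 10%
compound 3 `CCOC(=O)C1=C(Nc2cccc(F)c2)S/C(=C\c2ccc[nH]2)C1=O`: < 10%

Three compounds share one core. In a functional assay on MCF7 cells (Homo sapiens) for inhibition, read by MTT assay, with a stated time of 72 h, tested at 10 uM (a lower number here means less inhibition, a higher number more inhibition at the concentration tested (going by the name of the read-out)), compound 1 gives 18.3%. Compound 2 reaches only a limit of the assay, < 10%. Compound 3 likewise stands at a limit, < 10%, the floor described by the limit of < 10% in this assay, at which 2 of the 3 values shown sit. The steps of a number at least 8.3 percentage points lower from compound 1 to compound 2 (that floor lies within the scatter) and a number at least 8.3 percentage points lower from compound 1 to compound 3 (that floor lies within the scatter) lie within the scatter, and a step that the two limits leave unreadable from compound 2 to compound 3 cannot be read.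

Compound 4 `CCOC(=O)C1=C(Nc2cccc([N+](=O)[O-])c2)S/C(=C\c2ccc[nH]2)C1=O` differs from compound 3 by nitro in place of fluoro on an aromatic carbon. Going by the values given here, no measured step involves a nitro, and the only change seen at this place, fluoro in place of hydrogen, stayed within scatter. Compound 4 is therefore expected to remain near the floor, a step of a number at least 2 percentage points higher from compound 3 to compound 4 (that floor lies within the scatter) being the estimate. Compound 4 is estimated at 12%, with a range from 0% to 35%.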

Compound 4, a percentage reported as inhibition, at one concentration (the size of the read-out at that concentration, not a potency): 27.4%
Beside the measured number, compound 4's estimate is 15.4 percentage points below it, within the range that was stated.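

In this assay, the place meta to a large group now shows a change that exceeds the scatter: nitro in place of fluoro gives a number at least 17.4 percentage points higher from compound 3 to compound 4 (beyond the scatter), and 3-nitrophenyl in place of 4-fluorophenyl gives a number at least 17.4 percentage points higher from compound 2 to compound 4 (beyond the scatter). Both sizes are only floors, as each step starts from a limit: the limit of < 10% in this assay, at which 2 of the 4 values shown sit. Against hydrogen at this place, nitro gives a number 9.1 percentage points higher from compound 1 to compound 4 (within the scatter), so compound 4 stands apart only from compound 2 and compound 3.

From the compounds shown here alone, how an amine, a nitrile or a carboxylic acid would read at this place stays open. So does how nitro would read where compound 2 carries its fluoro.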